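This account rests on a few compounds, and the source may have more. Where it says the series, first, only, none or still open, it means among the compounds named here.

In a functional assay on Jurkat cells (Homo sapiens) for antiproliferative activity, read by WST assay, with a stated time of 72 h (on this read-out lower numbers stand for stronger inhibition and higher numbers for weaker inhibition), three compounds built on one shared core have been tested. Compound 1 `COc1ccc2[nH]c(-c3nc(-c4ccccc4)no3)cc2c1` gives > 50000 nM, which is a limit of the assay and not a number. Compound 2 `Clc1ccc2[nH]c(-c3nc(-c4ccccc4)no3)cc2c1` gives > 50000 nM, again only a limit. Compound 3 `Clc1ccc(-c2noc(-c3cc4ccccc4[nH]3)n2)cc1` likewise gives > 50000 nM, a limit. Compound 2 and compound 1 differ in a single place methoxy in place of chloro on an aromatic carbon and the step that the two limits leave unreadable from compound 2 to compound 1 stays unreadable, since both values are limits. How the core of compound 3 differs from that of compound 2 is not broken down here. Compound 4 `COc1ccc(-c2noc(-c3cc4ccccc4[nH]3)n2)cc1` has not yet been measured; it differs from compound 3 by methoxy in place of chloro on an aromatic carbon, the same kind of change as from compound 2 to compound 1, though here the place is on a ring of carbon only, para to a large group, rather than on a fused system of two rings. For the measured compounds named here, because every measured value sits at the limit of > 50000 nM in this assay, at which 3 of the 3 values shown sit, no step in this set can be read. Compound 4 is therefore expected to remain at the limit, the expected step that the limit leaves unreadable from compound 3 to compound 4 meaning no readable change. Compound 4 is estimated at 60000 nM, between 20000 nM and 200000 nM.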

Compound 4, half-maximal inhibitory concentration: > 50000 nM
Compound 4: no number, only a limit; the forecaster's own chance of this, stated with the estimate: 85%; the middle value does not contradict the limit.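

The change from compound 3 to compound 4, methoxy in place of chloro on an aromatic carbon, cannot be read as a step, because both values are limits of the assay and not numbers: the limit of > 50000 nM in this assay, at which 4 of the 4 values shown sit.

In this assay the compounds shown leave open which change to the shared core, if any, would give a measurable value.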